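The source may hold more compounds than are shown below. What is called first, only, known or untested is meant among the compounds shown, and "the series" means these compounds.

Measured so far in an ADME assay on HEL cells (Homo sapiens) for cytotoxicity, with a stated time of 3 days; on this read-out higher numbers stand for lower toxicity in this test and lower numbers for higher toxicity in this test:

Compound 1, `Cc1cc(-c2ccc(O)cc2)cn2c(CSCCc3ccccc3)cnc12`, gives > 50 ug/mL, which is a limit of the test and not a number.
Compound 2, `Cc1cc(I)cn2c(CSCCc3ccccc3)cnc12`, gives > 50 ug/mL, again a limit and not a number.
Compound 3, `COc1ccc(-c2cc(C)c3ncc(CSCCc4ccccc4)n3c2)cc1`, gives 25.8 ug/mL.

For the measured compounds named here, compound 3 therefore holds the only actual number among the three; the other two values sit at the limit of > 50 ug/mL in this assay, at which 2 of the 3 values shown sit. Compound 4, `Cc1cc(-c2cccc(O)c2)cn2c(CSCCc3ccccc3)cnc12`, differs from compound 3 in one place: 3-hydroxyphenyl in place of 4-methoxyphenyl on an aromatic carbon. Going by the values given here, two measured steps bear on this change. The step of an at least 1.9-fold lower number from compound 1 to compound 3 (0.28 log units; that floor lies within the scatter) put a methyl in place of hydrogen on an oxygen on an aromatic ring, and the step of an at least 1.9-fold lower number from compound 2 to compound 3 (0.28 log units; that floor lies within the scatter) put a 4-methoxyphenyl in place of iodo; both moved from a limit to the one number shown, and in both the floor lies within the scatter. Compound 4 undoes the methyl and carries a hydroxyphenyl again, much as compound 1 does, so the number is expected to move back up toward the limit, though the size cannot be read closely from steps whose floors sit within the scatter. Compound 4 is thus estimated at about 45 ug/mL, within 20 ug/mL to 100 ug/mL. That estimate means an expected step of a 1.7-fold higher number from compound 3 to compound 4 (0.24 log units; within the scatter).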

Compound 4, half-maximal cytotoxic concentration: 50 ug/mL
Compound 4: middle estimate off by 1.1-fold (0.05 log units), on the low side; measured number inside the range.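

In this assay, 3-hydroxyphenyl in place of 4-methoxyphenyl on an aromatic carbon gives a 1.9-fold higher number from compound 3 to compound 4 (0.29 log units; within the scatter). For the compounds shown here, this is the only step at this position with a real number at both ends, and it shows that these two aryl groups cannot be told apart in this test, so the single number of compound 3 marks no clear change at this position. The two other steps, a number no higher from compound 2 to compound 4 (the limit leaves the size open) and a number no higher from compound 1 to compound 4 (the limit leaves the size open), cannot be read because each starts from a limit, which hides their size: the limit of > 50 ug/mL in this assay, at which 2 of the 4 values shown sit.

The 3-hydroxyphenyl differs from the 4-methoxyphenyl both in where the oxygen sits on the ring and in the methyl group, and the compounds shown do not pull these two differences apart. From the compounds shown here alone, it also remains open whether an amine or a carboxylic acid on this aryl ring would move the number beyond the usual scatter of the test.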